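The source may hold more compounds than are shown below. What is called first, only, known or untested is meant among the compounds shown, and "the series" means these compounds.

Working notes on the series. Three measured compounds share one core and differ only in the group carried on the saturated chain carbon bound to a sulfur. Compound 1 `C/C(C#Cc1ccccc1)=N\N/C(N)=N/S(=O)(=O)c1cc(C)c(Cl)cc1SCc1ccccc1C(F)(F)F` gives 23000 nM in a functional assay on HCT-116 cells (Homo sapiens) for antiproliferative activity, read by MTT assay, with a stated time of 72 h; on this read-out lower numbers stand for stronger inhibition and higher numbers for weaker inhibition. Compound 2 `C/C(C#Cc1ccccc1)=N\N/C(N)=N/S(=O)(=O)c1cc(C)c(Cl)cc1SCc1ccc(C(F)(F)F)cc1` gives 160000 nM in this assay, and compound 3 `C/C(C#Cc1ccccc1)=N\N/C(N)=N/S(=O)(=O)c1cc(C)c(Cl)cc1SCc1cccc(Cl)c1` gives 119000 nM in this assay. Among the three numbers compound 3 stands second highest; its nearest neighbour is compound 2, with a 1.3-fold lower number from compound 2 to compound 3 (0.13 log units; within the scatter), while compound 1 lies furthest away, with a 5.2-fold higher number from compound 1 to compound 3 (0.71 log units; beyond the scatter).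

The change now followed leads to compound 4 `C/C(C#Cc1ccccc1)=N\N/C(N)=N/S(=O)(=O)c1cc(C)c(Cl)cc1SCc1cccc2ccccc12`: naphthalen-1-yl in place of 3-chlorophenyl on a saturated chain carbon bound to a sulfur. Among the measured compounds shown here, no measured step introduces naphthalen-1-yl at this place; the closest precedents are the exchanges of one substituted phenyl for another, namely a 7.0-fold higher number from compound 1 to compound 2 (0.84 log units; beyond the scatter) and a 5.2-fold higher number from compound 1 to compound 3 (0.71 log units; beyond the scatter), which show that the group on the saturated chain carbon bound to a sulfur can move the number by modest amounts, and a 1.3-fold lower number from compound 2 to compound 3 (0.13 log units; within the scatter), which stays within the scatter. A modest step is therefore plausible in this assay, with a lower number somewhat more likely than a higher one, though the direction is not fixed by the three compounds at hand. Compound 4 is expected to give 60000 nM, within 15000 nM to 200000 nM. That estimate corresponds to a 2.0-fold lower number from compound 3 to compound 4 (0.30 log units; within the scatter).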

Compound 4, half-maximal inhibitory concentration: 105000 nM
Beside the measured number, compound 4's estimate is 1.8-fold (0.24 log units) below it, and the stated range covers the measured number.
By their numbers in this assay, from the lowest: compound 1; then compounds 4, 3 and 2 (each within the scatter of the next).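

Naphthalen-1-yl brings a second six-membered aromatic ring and 10 heavy atoms in place of the single ring and 7 heavy atoms of 3-chlorophenyl on the saturated chain carbon bound to a sulfur, yet in this assay the result is a 1.1-fold lower number from compound 3 to compound 4 (0.05 log units; within the scatter) and a 1.5-fold lower number from compound 2 to compound 4 (0.18 log units; within the scatter). Compounds 2, 3 and 4 therefore form one group within the scatter, even though this change adds a fused ring rather than exchanging one substituent on a phenyl ring for another. Compound 1 remains the only one set apart, with a 4.6-fold higher number from compound 1 to compound 4 (0.66 log units; beyond the scatter), and its steps to the other three compounds are all beyond the scatter, so 2-(trifluoromethyl)phenyl gives the strongest inhibition of the four groups. No supporting measurement bears on this result, so the reading stops at the numbers themselves.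

The compounds shown leave open whether the number for compound 1 depends on the trifluoromethyl group itself or on where it stands on the phenyl ring. They also leave open how the number responds on this saturated chain carbon to a group outside the aromatic carbon rings, such as an amine, a carboxylic acid or a longer chain.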